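Swapping Isopropyl for Benzyl on a Urea Nitrogen

The source may report more compounds than this note shows. Statements on the series, on what has been measured and on what is new or still open speak of the compounds shown alone.

Measured so far:
compound 1 `CCCC(O)Cn1ncc(C(=O)OCC)c1NC(=O)NC(C)C` — 20 nM
compound 2 `CCOC(=O)c1cnn(CC(O)CC)c1NC(=O)NC(C)C` — > 10 nM (a limit of the assay)

Within the data shown here, in a functional assay on cells (Neutrophil, Homo sapiens) for inhibition, with a stated time of 10 min (a higher number here means a weaker inhibitor, a lower number a stronger inhibitor), compound 1 gives 20 nM, the only plain number among the measured compounds. Compound 2 differs from compound 1 by hydrogen in place of methyl on a saturated chain carbon, three bonds along the chain from an oxygen on a saturated carbon. For compound 2 the result > 10 nM is a limit of the assay, not a number. The step that the limit leaves unreadable from compound 1 to compound 2 therefore cannot be sized, which follows from the limit of > 10 nM in this assay, at which 1 of the 2 values shown sits.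

The unmeasured compound 3 `CCCC(O)Cn1ncc(C(=O)OCC)c1NC(=O)NCc1ccccc1` carries a different change: benzyl in place of isopropyl on an amide-type nitrogen. Among the measured compounds shown here, no measured step touches this amide-type nitrogen, so nothing measured sets the size of this step, and the expectation rests on compound 1 alone. Compound 3 is expected to stay close to compound 1, with the step of no change at the digits printed from compound 1 to compound 3 (within the scatter) expected to remain within the usual scatter. The estimate for compound 3 is 20 nM, ranging from 5 nM to 100 nM.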

Compound 3, half-maximal inhibitory concentration: 0.43 nM
For compound 3 the middle estimate is 47-fold (1.67 log units) above the measured one; the measured number lies below the stated range.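

In this assay, the result turns on what sits at this amide-type nitrogen: benzyl in place of isopropyl gives a 47-fold lower number from compound 1 to compound 3 (1.67 log units; beyond the scatter) and so a far stronger inhibitor. Among these compounds, the earlier step lay elsewhere in the molecule and cannot be read, since compound 2 gives only a limit of the assay, so this is the first sized change. Nothing measured among these compounds explains why the number falls so far.

Going by these compounds, it remains open whether the aromatic ring matters or simply the larger group, which cyclohexylmethyl or a longer chain such as n-butyl on the same nitrogen could separate. Also open, on these data alone, is how a fluorine or a methoxy group on the benzyl ring, or a phenethyl group in its place, would compare with compound 3.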